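Phenyl for Pyridin-4-yl: Expected Cytotoxicity of Compound 4

This account rests on a few compounds, and the source may have more. Where it says the series, first, only, none or still open, it means among the compounds named here.

Compound 1 `Cc1cc(C)cc(S(=O)(=O)c2c(C(=O)NC(C)C(=O)NC(C)c3ccncc3)[nH]c3ccc(Cl)cc23)c1`: 21900 nM
Compound 2 `Cc1cc(C)cc(S(=O)(=O)c2c(C(=O)NC(c3ccc(Cl)cc3)C3CC3)[nH]c3ccc(Cl)cc23)c1`: > 47300 nM (a limit)
Compound 3 `Cc1cc(C)cc(S(=O)(=O)c2c(C(=O)NCc3ccc4nc(N)[nH]c4c3)[nH]c3ccc(Cl)cc23)c1`: 5890 nM

In an ADME assay on MT4 cells (Homo sapiens) for cytotoxicity, read by MTT assay (a higher number here means that more compound is tolerated, a lower number that less compound is tolerated), compound 1 gives 21900 nM, the highest of the two numbers, with compound 3 the nearest at 5890 nM. Compound 2 reaches only the limit of > 47300 nM in this assay, at which 1 of the 3 values shown sits, and so yields no number. Going by the values given here, the one measured step, an at least 8.0-fold lower number from compound 2 to compound 3 (0.90 log units; beyond the scatter), replaces the group on the amide-type nitrogen and does not touch the part that changes in compound 4 `Cc1cc(C)cc(S(=O)(=O)c2c(C(=O)NC(C)C(=O)NC(C)c3ccccc3)[nH]c3ccc(Cl)cc23)c1`, which carries phenyl in place of pyridin-4-yl on a saturated chain carbon bound to an amide-type nitrogen and a saturated chain carbon. Among the compounds with values here, no measured step bears on this change, so the expectation rests on compound 1 alone, and a step within the scatter is expected: a 1.4-fold lower number from compound 1 to compound 4 (0.14 log units; within the scatter). Compound 4 is therefore estimated at 16000 nM, with a range from 7000 nM to 40000 nM.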

Compound 4, half-maximal cytotoxic concentration: 21700 nM
Compound 4: middle estimate off by 1.4-fold (0.13 log units), on the low side; measured number inside the range.
By their numbers in this assay, from the lowest: compound 3; then compounds 4 and 1 (each within the scatter of the next). At a limit, above all of these: compound 2.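

Replacing pyridin-4-yl with phenyl on a saturated chain carbon bound to an amide-type nitrogen and a saturated chain carbon gives, in this assay, a 1.0-fold lower number from compound 1 to compound 4 (0.00 log units; within the scatter), so this read-out does not separate the two rings. Going by these compounds alone, no earlier step touched this place, and this is the first reading of it. Nothing available accounts for this result.

The compounds shown leave open whether a phenyl carrying an amine or a carboxylic acid would also leave this read-out in place. As far as these compounds go, a longer chain between the ring and the amide-type nitrogen also remains open.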